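The source may hold more compounds than are shown below. What is called first, only, known or untested is meant among the compounds shown, and "the series" means these compounds.

Measured compounds in a functional assay on L1210 cells (Mus musculus) for cytotoxicity; on this read-out higher numbers stand for weaker inhibition and lower numbers for stronger inhibition:
- compound 1 `C=C1C(n2cc(F)c(=O)[nH]c2=O)O[C@H](CO)[C@@H]1O` gives > 100 ug/mL, a limit of the assay and not a number.
- compound 2 `C=C1C(n2cc(Br)c(=O)[nH]c2=O)O[C@H](CO)[C@@H]1O` gives > 100 ug/mL, likewise a limit of the assay.
- compound 3 `C=C1C(n2cc(C)c(=O)[nH]c2=O)O[C@H](CO)[C@@H]1O` gives 50 ug/mL.

Going by the values given here, compound 3 thus holds the only number in this assay; the other two values sit at the limit (the limit of > 100 ug/mL in this assay, at which 2 of the 3 values shown sit). The halogen-to-methyl steps an at least 2.0-fold lower number from compound 1 to compound 3 (0.30 log units; that floor lies within the scatter) and an at least 2.0-fold lower number from compound 2 to compound 3 (0.30 log units; that floor lies within the scatter) show only floors, and a step that the two limits leave unreadable from compound 1 to compound 2 cannot be read. Compound 4 `C=C1C(n2cc(CC)c(=O)[nH]c2=O)O[C@H](CO)[C@@H]1O` carries the change (methyl in place of hydrogen on a saturated chain carbon bound to an aromatic carbon). Among the compounds with values here, no measured step concerns this change, and the steps seen give no readable size beyond their floors, so in this assay no step beyond the scatter is expected. Compound 4 is estimated at 60 ug/mL, within 20 ug/mL to 150 ug/mL. The expected step of a 1.2-fold higher number from compound 3 to compound 4 (0.08 log units; within the scatter) is accordingly small.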

Compound 4, half-maximal inhibitory concentration: > 100 ug/mL
Compound 4 gave a limit, no number; the forecaster's own chance of this, stated with the estimate: 30%; middle value at least 1.6-fold (0.22 log units) from the limit.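

In this assay compound 4 gives > 100 ug/mL, a limit of the assay and not a number. Methyl to ethyl gives an at least 2.0-fold higher number from compound 3 to compound 4 (0.30 log units; that floor lies within the scatter): ethyl brings no gain over methyl here, and the true size of the step stays unknown, while the steps from the two halogen compounds cannot be read. Only methyl now gives a number in this small set: the limit of > 100 ug/mL in this assay, at which 3 of the 4 values shown sit.

From the compounds shown here alone, whether a propyl chain, a hydroxymethyl group or an amine in place of the ethyl would give a readable number stays open.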